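Swapping a phenyl for a chlorine-bearing chain

The compounds below may be only part of what the source reports. "The series", "measured", "known", "first", "only" and "open" are said of these compounds alone.

Compound 1 `C=C(C(=O)OC)[C@@H]1CC[C@H](C)[C@H]2C(=C(C)C(=O)[C@H]2NC(C)=O)C1` gives 753 uM
Compound 2 `C=C(C(=O)OC)[C@@H]1CC[C@H](C)[C@H]2C(=C(C)C(=O)[C@H]2NC(=O)c2ccccc2)C1` gives 84.3 uM

Going by the values given here, both numbers come from an ADME assay on MDCK cells (Canis lupus familiaris) for cytotoxicity, with a stated time of 48 h (on this read-out lower numbers stand for higher toxicity in this test and higher numbers for lower toxicity in this test), and they are the only measurements so far. Among the compounds with values here, of the two, compound 2 has the lower number and so shows the higher toxicity in this test, while its only neighbour, compound 1, stands at 753 uM on the same scale.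

The next compound, compound 3 `C=C(C(=O)OC)[C@@H]1CC[C@H](C)[C@H]2C(=C(C)C(=O)[C@H]2NC(=O)C(C)CCl)C1`, keeps the shared core and differs from compound 2 in one place: a group of 4 heavy atoms (3 carbon, 1 chlorine; no ring) in place of a group of 6 heavy atoms (6 carbon; one six-membered aromatic ring of carbon only), on a carbonyl carbon is the whole change.

Within the data shown here, one measured step bears on this. It is an 8.9-fold lower number from compound 1 to compound 2 (0.95 log units; beyond the scatter) with phenyl in place of methyl on a carbonyl carbon, a modest step beyond the scatter. Among the measured compounds shown here, compound 3 also lacks the phenyl, but no measured compound carries chlorine, so what that atom adds is unknown. Only part of the earlier step is therefore expected to return, towards a higher number. The expected move is a 2.4-fold higher number from compound 2 to compound 3 (0.38 log units; beyond the scatter) in this assay as a rough estimate. For compound 3 the estimate is 200 uM within an expected range of 60 uM to 600 uM on this scale.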

Compound 3, half-maximal toxic concentration: 735 uM
Beside the measured number, compound 3's estimate is 3.7-fold (0.57 log units) below it; measured number outside the range, above it.
By their numbers in this assay, from the lowest: compound 2; then compounds 3 and 1 (each within the scatter of the next).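

In this assay the move away from phenyl on this carbonyl carbon brings an 8.7-fold higher number from compound 2 to compound 3 (0.94 log units; beyond the scatter) and so shows that the lower number of compound 2 does not carry over to this non-ring chlorine-bearing group. The comparison with the methyl-bearing amide gives a 1.0-fold lower number from compound 1 to compound 3 (0.01 log units; within the scatter) and adds a second point: a group of 4 heavy atoms containing chlorine and a single carbon atom cannot be told apart at this place, which leaves the phenyl compound, compound 2, as the only one of the three that stands apart. Nothing measured here accounts for that difference.

Compound 3 differs from compound 1 in both chain size and chlorine, so the separate contribution of the chlorine stays unresolved, and an otherwise matching chain with no chlorine would address it. Going by these compounds, whether the lower number belongs to phenyl alone or extends to other rings also stays open, and a cyclohexyl group or a pyridine ring on the same carbonyl carbon would begin to answer that.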